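A few compounds are considered here, and "the series" means these few. Any claim that something is new, unique, unknown or untested is made for them only; others in the source may bear on it.

Compound 3 `CCOC(=O)c1cnc(C2CC2)nc1NN1C(=O)C=C(C)C1=O` stands second highest among the three numbers in a functional assay on Jurkat cells for inhibition of nuclear factor NF-kappa-B complex (Homo sapiens) (a lower number here means a stronger inhibitor, a higher number a weaker inhibitor), where compound 3 gives 1000 nM; compound 2 `CCOC(=O)c1cnc(-c2ccc(Cl)s2)nc1NN1C(=O)C=C(C)C1=O` gives 300 nM and compound 1 `CCOC(=O)c1cnc(-c2cccc(OC)c2)nc1NN1C(=O)C=C(C)C1=O` gives 5000 nM. The unmeasured compound 4 `CCOC(=O)c1cnc(CC2=CCCCC2)nc1NN1C(=O)C=C(C)C1=O` differs from compound 3 by (cyclohex-1-en-1-yl)methyl in place of cyclopropyl on an aromatic carbon. The changes that bear on this position are a 5.0-fold lower number from compound 1 to compound 3 (0.70 log units; beyond the scatter) and a 3.3-fold higher number from compound 2 to compound 3 (0.52 log units; beyond the scatter), while a 17-fold lower number from compound 1 to compound 2 (1.22 log units; beyond the scatter) shows how widely groups at this carbon can spread the numbers. No measured change places a six-membered non-aromatic ring at this carbon, so the direction for compound 4 is uncertain. Compound 4 is expected to give 1000 nM in this assay, with a range from 300 nM to 3000 nM. The expected step from compound 3 is no change at the digits printed from compound 3 to compound 4 (within the scatter), which may stay within the scatter.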

Compound 4, half-maximal inhibitory concentration: 2000 nM
The estimate for compound 4 lay 2.0-fold (0.30 log units) below the measured number; measured number inside the range.
By their numbers in this assay, from the lowest: compound 2; then compounds 3 and 4 (each within the scatter of the next); then compound 1.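

In this assay, (cyclohex-1-en-1-yl)methyl brings a six-membered non-aromatic ring to this carbon and stays within the scatter of cyclopropyl (a 2.0-fold higher number from compound 3 to compound 4 (0.30 log units; within the scatter)). It does not reach the number of the 5-chlorothiophen-2-yl group (a 6.7-fold higher number from compound 2 to compound 4 (0.82 log units; beyond the scatter)) but still improves on 3-methoxyphenyl (a 2.5-fold lower number from compound 1 to compound 4 (0.40 log units; beyond the scatter)). Nothing measured explains these differences. The compounds shown leave open how an amine or a carboxylic acid at this carbon would read in this assay. They also leave open whether a plain cyclohexyl group would differ from the cyclohexenylmethyl group.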